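Removing a methyl from the aryl oxygen of compound 2

This account rests on a few compounds, and the source may have more. Where it says the series, first, only, none or still open, it means among the compounds named here.

Measured compounds in a functional assay on ACHN cells (Homo sapiens) for antiproliferative activity, read by sulforhodamine B assay; on this read-out higher numbers stand for weaker inhibition of growth and lower numbers for stronger inhibition of growth:
- compound 1 `O=C(/C=C/c1ccc(O)cc1)c1c(O)cccc1OCC1CCCCC1`: > 30000 nM
- compound 2 `COc1cccc(OCCC(C)(C)C)c1C(=O)/C=C/c1ccc(O)cc1`: > 30000 nM
- compound 3 `O=C(/C=C/c1ccc(O)cc1)c1c(O)cccc1OCC1CCCC1`: 3510 nM

The values of compound 1 and compound 2 are limits of this assay, not numbers; only compound 3 gives a measured number. Among the measured steps, the only one available is an at least 8.5-fold lower number from compound 1 to compound 3 (0.93 log units; beyond the scatter), and it concerns a different part of the molecule. Compound 4 `CC(C)(C)CCOc1cccc(O)c1C(=O)/C=C/c1ccc(O)cc1` differs from compound 2 by hydrogen in place of methyl on an oxygen on an aromatic ring. Among the compounds with values here, no measured step reports what this change does, so there is nothing to scale an expectation from. Compound 2 sits at the limit, and the hydroxy analogues compound 1 and compound 3 span both a limit and a measured number, so a wide range is expected for compound 4. The step expected is an at least 2.5-fold lower number from compound 2 to compound 4 (0.39 log units; beyond the scatter), with an appreciable chance that only a limit is reported. Compound 4 is therefore estimated at 12000 nM, between 2500 nM and 40000 nM.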

Compound 4, concentration for 50% growth inhibition: 3140 nM
Compound 4: middle estimate off by 3.8-fold (0.58 log units), on the high side; measured number inside the range.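

In this assay, within the data shown here, this is the first view of the oxygen that carries the methyl, and methoxy to hydroxy there gives an at least 9.5-fold lower number from compound 2 to compound 4 (0.98 log units; beyond the scatter). With the hydroxy in place, the chain on the other aryl oxygen can also be compared: neopentyl gives an at least 9.5-fold lower number from compound 1 to compound 4 (0.98 log units; beyond the scatter), while the change from cyclopentyl gives a 1.1-fold lower number from compound 3 to compound 4 (0.05 log units; within the scatter), so these two chains cannot be told apart here. The full size of the two larger steps cannot be read because each starts from a limit of the assay rather than a number: the limit of > 30000 nM in this assay, at which 2 of the 4 values shown sit.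

Among these compounds, the methoxy to hydroxy change is seen only with the neopentyl chain, so whether it holds with other chains stays open. Going by these compounds, it is also open how an amine in place of the hydroxy, or a longer chain in place of neopentyl, would affect growth inhibition.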